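This account rests on a few compounds, and the source may have more. Where it says the series, first, only, none or still open, it means among the compounds named here.

Compound 1 `COc1cc2c(cc1OC)C(CC(=O)Nc1ccccc1)CC2` is tested in a functional assay on the whole organism (strain Wistar) for inhibition, with Rattus norvegicus as the target, read by paw edema, with a stated time of 6 h, at a dose of 100 mg/kg (on this read-out lower numbers stand for less inhibition and higher numbers for more inhibition at the one dose given (going by the name of the read-out)), where compound 1 gives 38.9%. Among the three measured compounds, compound 1 stands second highest: compound 2 `COc1cc2c(cc1OC)C(CC(=O)Nc1ccc(Br)cc1)CC2` gives 46.3%, and compound 3 `COc1ccccc1NC(=O)CC1CCc2cc(OC)c(OC)cc21` gives 24.1%. Compound 4 `COc1cc2c(cc1OC)C(CC(=O)Nc1ccccn1)CC2` differs from compound 1 in one place: pyridin-2-yl in place of phenyl on an amide-type nitrogen. The measured steps that bear on this all alter the group on the amide-type nitrogen: a number 7.4 percentage points higher from compound 1 to compound 2 (within the scatter), a number 14.8 percentage points lower from compound 1 to compound 3 (beyond the scatter), and a number 22.2 percentage points lower from compound 2 to compound 3 (beyond the scatter). None of them puts a hetero atom into that aromatic ring, so the present change has no close parallel; a step of modest size at most is expected, possibly none beyond the scatter. Compound 4 is therefore estimated at 37%, within a range from 24% to 50%. For compound 4 the expected step is a number 1.9 percentage points lower from compound 1 to compound 4 (within the scatter).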

Compound 4, a percentage reported as inhibition, in the whole organism at one dose (the size of the read-out at that dose, not a potency): 29.6%
Estimate against measurement, compound 4: 7.4 percentage points above, and the stated range covers the measured number.
By their numbers in this assay, from the lowest: compounds 3, 4, 1 and 2 (each within the scatter of the next, the first and the last beyond it).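

Placing a hetero atom in the aromatic ring on the amide-type nitrogen gives a number 9.3 percentage points lower from compound 1 to compound 4 (within the scatter) and so does not separate pyridin-2-yl from phenyl beyond the usual scatter. Pyridin-2-yl and 2-methoxyphenyl also stay together, with a number 5.5 percentage points higher from compound 3 to compound 4 (within the scatter), while 4-bromophenyl stands apart from pyridin-2-yl, with a number 16.7 percentage points lower from compound 2 to compound 4 (beyond the scatter). Nothing measured here gives a reason for these steps. The compounds shown leave open how pyridin-3-yl or pyridin-4-yl would read on the same nitrogen, and whether an amine on the pyridin-2-yl ring would shift the number.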